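A few compounds are considered here, and "the series" means these few. Any claim that something is new, unique, unknown or untested is made for them only; others in the source may bear on it.

Three compounds have been measured so far in an ADME assay on Vero cells (Chlorocebus sabaeus) for cytotoxicity, read by MTT assay, with a stated time of 72 h; on this read-out higher numbers stand for lower toxicity in this test and lower numbers for higher toxicity in this test:

Compound 1, `Cc1nnc(C2(O)CC(C)CC(C)(C)C2)[nH]1`, gives 380 ug/mL.
Compound 2, `Cc1nnc(C(O)C2CCC(O)C(O)C2)[nH]1`, gives 378 ug/mL.
Compound 3, `CC1CC(C)(C)CC(O)(c2nnc(-c3ccccc3)[nH]2)C1`, gives 383 ug/mL.

Compound 3 differs from compound 1 in one place only, (phenyl in place of methyl on an aromatic carbon). The step this change made in this assay is a 1.0-fold higher number from compound 1 to compound 3 (0.00 log units; within the scatter), so the larger group left the read-out where it was. Compound 2 shares the same five-membered aromatic ring with compound 1 but carries a different substituted part; the difference between the two cores is not broken down here. Compound 1 and compound 2 give numbers in this assay that lie within the usual scatter of each other.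

Compound 4, `OC1CCC(C(O)c2nnc(-c3ccccc3)[nH]2)CC1O`, has not been measured yet. It differs from compound 2 by phenyl in place of methyl on an aromatic carbon, and the place of the change is described in the same words as for the pair of compound 1 and compound 3, so it is the same change made on the other core. Set beside a 1.0-fold higher number from compound 1 to compound 3 (0.00 log units; within the scatter), the step from compound 2 to compound 4 in this assay is expected to be a 1.0-fold higher number from compound 2 to compound 4 (0.00 log units; within the scatter), because the same change made no difference to compound 3 relative to compound 1 and because compound 2 starts from 378 ug/mL. Compound 4 is therefore estimated at 380 ug/mL, with a likely range from 230 ug/mL to 520 ug/mL.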

Compound 4, half-maximal cytotoxic concentration: 429 ug/mL
Compound 4: the middle estimate sits 1.1-fold (0.05 log units) below what was measured, within the range that was stated.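

In this assay, phenyl in place of methyl on an aromatic carbon gives a 1.1-fold higher number from compound 2 to compound 4 (0.05 log units; within the scatter), so on this second core too the larger group left the read-out within the usual scatter. Set beside the earlier step, the change behaves alike on the two cores: the same change on two cores in this assay, a 1.0-fold higher number (0.00 log units; within the scatter) from compound 1 to compound 3 and a 1.1-fold higher number (0.05 log units; within the scatter) from compound 2 to compound 4, 1.1-fold (0.05 log units) apart, within the scatter of two such steps. This shows that, for these two pairs, the result of the change carried over from one core to the other; it does not show that the same would hold on a third core, and with neither step beyond the scatter, these pairs cannot show whether a clear rise or fall in the number would carry over as well.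

The compounds shown hold only methyl and phenyl on this aromatic carbon, so it remains open whether an amine, a carboxylic acid or a longer chain there would also leave the number in this assay within the scatter. On these data alone, it also remains open whether a phenyl bearing a further group, such as a chlorine atom or a methoxy group, would behave like the plain phenyl on either core.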